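The source may report more compounds than this note shows. Statements on the series, on what has been measured and on what is new or still open speak of the compounds shown alone.

Compound 1 `CC(C)/C(=C1\C(=O)NC(=O)N1C)c1ccc(-c2ccc3cccc(F)c3c2)[nH]c1=O`: 6.85 10^-6 cm/s in an ADME assay on MDCK cells (Canis lupus familiaris) for permeability, in the apical to basolateral direction; on this read-out lower numbers stand for lower permeability and higher numbers for higher permeability.
Compound 2 `CC(C)C(/C=C1\NC(=O)NC1=O)c1ccc(-c2ccc3cccc(F)c3c2)[nH]c1=O`: 12.3 10^-6 cm/s in this assay.
Compound 3 `CC(C)[C@H](C[C@@H]1OC(=O)NC1=O)c1ccc(-c2ccc3cccc(F)c3c2)[nH]c1=O`: 10.8 10^-6 cm/s in this assay.

The three measured compounds share a core and differ in the five-membered ring attached to it. Compound 2 gives the largest of the three numbers in this assay, yet its gap to compound 3 and its gap to compound 1 both fall within the usual scatter, so none of the three can be set apart from the others on these data.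

Compound 4 `CC(C)C(/C=C1\SC(=O)NC1=O)c1ccc(-c2ccc3cccc(F)c3c2)[nH]c1=O` has not yet been measured. It differs from compound 2 by a group of 8 heavy atoms (4 carbon, 1 nitrogen, 2 oxygen, 1 sulfur; one five-membered non-aromatic ring with 2 hetero atoms) in place of a group of 8 heavy atoms (4 carbon, 2 nitrogen, 2 oxygen; one five-membered non-aromatic ring with 2 hetero atoms), on a saturated chain carbon bound to an aromatic carbon and a saturated chain carbon. Going by the values given here, no step between measured compounds of this kind is available, so the expectation rests on compound 2 alone. The number for compound 4 is expected to stay close to that of compound 2, with a step of a 1.1-fold higher number from compound 2 to compound 4 (0.06 log units; within the scatter), which would lie within the scatter. Compound 4 is therefore estimated at 14 10^-6 cm/s, in the range 7 10^-6 cm/s to 28 10^-6 cm/s.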

Compound 4, apparent permeability: 15.4 10^-6 cm/s
Compound 4: middle estimate off by 1.1-fold (0.04 log units), on the low side, and the stated range covers the measured number.
By their numbers in this assay, from the lowest: compounds 1, 3, 2 and 4 (each within the scatter of the next, the first and the last beyond it).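

Going by these compounds alone, compound 2 and compound 4 form the first pair in this set that differs in one place only, which gives the earlier compounds' comparison something they could not offer: a reading of a single ring exchange. In this assay, placing the sulfur-containing ring, with 1 hydrogen-bond donor and 3 hydrogen-bond acceptors, where the ring with 2 hydrogen-bond donors and 2 hydrogen-bond acceptors stood, on a saturated chain carbon bound to an aromatic carbon and a saturated chain carbon, gives a 1.3-fold higher number from compound 2 to compound 4 (0.10 log units; within the scatter), so the two compounds cannot be told apart on this read-out. No measurement shown here offers an explanation for this step.

This single step covers one exchange only. On these data alone, how a carboxylic acid or an amine at this same place would read in this assay remains open.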